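The source may hold more compounds than are shown below. What is called first, only, known or untested is meant among the compounds shown, and "the series" means these compounds.

Compound 3 `Cc1ccc(CSc2nc(C(F)(F)F)ccc2CNC(=O)C(C)c2ccc(NS(C)(=O)=O)c(F)c2)cc1` gives 3.2 nM in an assay on CHO-K1 cells for antagonist activity at transient receptor potential cation channel subfamily V member 1 (Homo sapiens), read by FLIPR; on this read-out lower numbers stand for stronger inhibition and higher numbers for weaker inhibition. Of the three measured compounds, compound 1 `CCCCCSc1nc(C(F)(F)F)ccc1CNC(=O)C(C)c1ccc(NS(C)(=O)=O)c(F)c1` gives 2.5 nM, a number within the scatter of that of compound 3, while compound 2 `CC(C(=O)NCc1ccc(C(F)(F)F)nc1SCc1ccc(Cl)cc1)c1ccc(NS(C)(=O)=O)c(F)c1` gives 8.7 nM. Compound 4 `COc1ccc(CSc2nc(C(F)(F)F)ccc2CNC(=O)C(C)c2ccc(NS(C)(=O)=O)c(F)c2)cc1` differs from compound 3 by methoxy in place of methyl on an aromatic carbon. The step that bears most directly on this change is a 2.7-fold lower number from compound 2 to compound 3 (0.43 log units; beyond the scatter), at the same aromatic carbon para to a large group; also relevant is a 1.3-fold higher number from compound 1 to compound 3 (0.11 log units; within the scatter). Among the compounds with values here, no measured step exchanges methyl for methoxy, so the direction is uncertain. A shift within the scatter is therefore expected, as a 1.4-fold higher number from compound 3 to compound 4 (0.15 log units; within the scatter). Compound 4 is estimated at 4.5 nM, with a range from 1.5 nM to 13 nM.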

Compound 4, inhibition constant: 2.3 nM
Estimate against measurement, compound 4: 2.0-fold (0.29 log units) above; the range from low to high includes it.
By their numbers in this assay, from the lowest: compounds 4, 1 and 3 (each within the scatter of the next); then compound 2.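

Methoxy in place of methyl on this aromatic carbon, para to a large group, leaves the number within the scatter (a 1.4-fold lower number from compound 3 to compound 4 (0.14 log units; within the scatter)), and the 4-methoxyphenyl group also stays within the scatter of butyl on the saturated chain carbon bound to a sulfur (a 1.1-fold lower number from compound 1 to compound 4 (0.04 log units; within the scatter)). Chloro alone stands apart among the three groups at this aromatic carbon, now against methoxy as well as methyl (a 3.8-fold lower number from compound 2 to compound 4 (0.58 log units; beyond the scatter)). Nothing in the data accounts for this gap. As far as these compounds go, whether ethoxy, an amine or a carboxylic acid at this carbon would fall with methyl and methoxy or with chloro remains open.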